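Acid series on the shared core: methyl to methoxy

The source may report more compounds than this note shows. Statements on the series, on what has been measured and on what is new or still open speak of the compounds shown alone.

Compound 1, `CCOC(=O)C1=Cc2ccccc2OC1(OCc1cc(-c2ccc(C)cc2)no1)C(F)(F)F`: > 150000 nM in a functional assay on A549 cells (Homo sapiens) for inhibition, read by MTT assay, with a stated time of 24 h (on this read-out higher numbers stand for weaker inhibition and lower numbers for stronger inhibition), which is a limit of the assay.
Compound 2, `Cc1ccc(-c2cc(COC3(C(F)(F)F)Oc4ccccc4C=C3C(=O)O)on2)cc1`: 51200 nM in this assay.
Compound 3, `CCOC(=O)C1=Cc2ccccc2OC1(OCc1cn(-c2cccc(C(F)(F)F)c2)nn1)C(F)(F)F`: > 150000 nM in this assay, which is a limit of the assay.

Among the compounds with values here, compound 2 holds the only number so far in this assay. The other two entries are limits, as summed up in the limit of > 150000 nM in this assay, at which 2 of the 3 values shown sit, so compound 2 cannot be ranked against them beyond saying that it alone gave a number. One step is measured, an at least 2.9-fold lower number from compound 1 to compound 2 (0.46 log units; beyond the scatter), and it concerns the ester-to-acid change, not the aryl group.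

Compound 4, `COc1ccc(-c2cc(COC3(C(F)(F)F)Oc4ccccc4C=C3C(=O)O)on2)cc1`, keeps the acid of compound 2 and differs only by methoxy in place of methyl on an aromatic carbon. Within the data shown here, no measured step touches this position, so the expectation rests on the step from compound 1 to compound 2 not at all, and simply on compound 2 as the nearest measured point. The number for compound 4 is therefore expected to stay within the scatter of compound 2. Compound 4 is estimated at 50000 nM in this assay, with a range from 20000 nM to 130000 nM. The expected step is a 1.0-fold lower number from compound 2 to compound 4 (0.01 log units; within the scatter), which is no change beyond the scatter.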

Compound 4, half-maximal inhibitory concentration: 36200 nM
Estimate against measurement, compound 4: 1.4-fold (0.14 log units) above; the range from low to high includes it.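

Moving from 4-methylphenyl to 4-methoxyphenyl with the acid held in place gives a 1.4-fold lower number from compound 2 to compound 4 (0.15 log units; within the scatter) in this assay, the first measured step at this position. On an aromatic carbon para to a large group, methoxy in place of methyl therefore does not separate compound 2 from compound 4 on this read-out, and both acids still give numbers. The reading rests on this single pair, since the other compounds shown give no numbers to compare: the limit of > 150000 nM in this assay, at which 2 of the 4 values shown sit.

Open, from the compounds shown here alone, is how this position responds to groups other than methyl and methoxy, such as a chlorine, an amine or a longer chain. Also open, going by these compounds, is whether the ester-to-acid step seen with compound 1 carries over to the side chain of compound 3, which stands only as a limit.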